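From Methyl to Twin Hydroxyls on the Benzyl Arm

The source may report more compounds than this note shows. Statements on the series, on what has been measured and on what is new or still open speak of the compounds shown alone.

Compound 1 `Cc1cccc(CNc2ncnc3c2ncn3[C@@H]2O[C@H](CO)[C@@H](O)[C@H]2O)c1` shows in a functional assay on K562 cells (Homo sapiens) for antiproliferative activity, with a stated time of 72 h (a lower number here means a stronger inhibitor, a higher number a weaker inhibitor), only a limit, > 166000 nM, and so stands at the limit of > 166000 nM in this assay, at which 1 of the 2 values shown sits. Compound 2 `OC[C@H]1O[C@@H](n2cnc3c(NCc4ccc(F)c(Cl)c4)ncnc32)[C@H](O)[C@@H]1O` gives 5500 nM in this assay. Among the measured compounds shown here, the single measured step, an at least 30-fold lower number from compound 1 to compound 2 (1.47 log units; beyond the scatter), shows that a different ring on this arm can move the number a long way. Compound 3 `OC[C@H]1O[C@@H](n2cnc3c(NCc4cc(O)cc(O)c4)ncnc32)[C@H](O)[C@@H]1O` carries 3,5-dihydroxyphenyl in place of 3-methylphenyl on a saturated chain carbon bound to a nitrogen on an aromatic ring. For the measured compounds named here, no measured step reaches a ring bearing hydroxyls, so the direction from compound 1 is open. One expects for compound 3 an at least 2.7-fold lower number from compound 1 to compound 3 (0.44 log units; beyond the scatter), with a real chance that only a limit is reported again. Compound 3 is estimated at 60000 nM, between 10000 nM and 300000 nM.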

Compound 3, half-maximal inhibitory concentration: > 166000 nM
Compound 3 gave a limit, no number; the forecaster's own chance of this, stated with the estimate: 50%; middle value at least 2.7-fold (0.44 log units) from the limit.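

In this assay compound 3 gives only a limit, > 166000 nM. Putting 3,5-dihydroxyphenyl in place of 3-chloro-4-fluorophenyl on this arm gives an at least 30-fold higher number from compound 2 to compound 3 (1.47 log units; beyond the scatter), so the gain seen with the halogenated ring does not carry over to a ring bearing hydroxyls. The step between compound 1 and compound 3 cannot be read, and the two arms now end at one limit: the limit of > 166000 nM in this assay, at which 2 of the 3 values shown sit.

As far as these compounds go, whether the hydroxyl-bearing ring differs at all from the 3-methylphenyl ring stays open. Also open, from the compounds shown here alone, is what a ring with chlorine alone, fluorine alone, an amine or a carboxylic acid would give.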